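The source may hold more compounds than are shown below. What is called first, only, known or untested is meant among the compounds shown, and "the series" means these compounds.

Of the compounds shown here, two of a shared core have been measured in an assay on CHO cells for displacement of a labelled ligand from adenosine receptor A1 (Homo sapiens); on this read-out lower numbers stand for stronger inhibition and higher numbers for weaker inhibition. Compound 1 `COc1ccc(CNc2ncc(C(=O)O)c3nc(-c4ccco4)nn23)cc1OC` gives 958 nM. Compound 2 `CCOC(=O)c1cnc(NC2CC2)n2nc(-c3ccco3)nc12` gives 60.7 nM. Among the measured compounds shown here, on these two numbers compound 2 stands lowest; its only neighbour is compound 1, whose number is higher by a margin beyond the scatter, so compound 2 is the stronger inhibitor of the pair.

Compound 3 `CCOC(=O)c1cnc(NC2CCCC2)n2nc(-c3ccco3)nc12` has not yet been measured. It differs from compound 2 in one place: cyclopentyl in place of cyclopropyl on a nitrogen on an aromatic ring. For the measured compounds named here, no measured pair shows this exact change, so its size must be guessed. Starting from the value of compound 2, 60.7 nM, a modest move toward a lower number is expected, about a 2.0-fold lower number from compound 2 to compound 3 (0.31 log units; beyond the scatter). Compound 3 is therefore estimated at 30 nM, with a range from 8 nM to 120 nM.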

Compound 3, inhibition constant: 34.4 nM
Estimate against measurement, compound 3: 1.1-fold (0.06 log units) below; measured number inside the range.
By their numbers in this assay, from the lowest: compounds 3 and 2 (each within the scatter of the next); then compound 1.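

In this assay, among the compounds shown here, putting cyclopentyl in place of cyclopropyl on a nitrogen on an aromatic ring gives a 1.8-fold lower number from compound 2 to compound 3 (0.25 log units; within the scatter), the first comparison here in which only one place differs. This step stays within the usual variation between repeated measurements, so compound 2 and compound 3 cannot be told apart on this read-out, and this position tolerates either ring with no clear gain or loss. No independent evidence is available to explain this result.

Still open, from the compounds shown here alone, is whether a larger ring such as cyclohexyl, or an open chain such as n-butyl, on the same nitrogen would keep the number in this range or shift it clearly. A single step between two small rings also cannot show how far this tolerance extends.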